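The source may hold more compounds than are shown below. What is called first, only, known or untested is meant among the compounds shown, and "the series" means these compounds.

Measured compounds:

- Compound 1 `O=C(O)Cc1sc(COc2ccc(Cl)cc2)nc1-c1ccc(Cl)cc1` — 50%
- Compound 2 `O=C(O)Cc1sc(C(c2ccc(F)cc2)c2ccc(F)cc2)nc1-c1ccnc(F)c1` — 80%
- Compound 3 `O=C(O)Cc1sc(C(c2ccccc2)c2ccc(Cl)cc2)nc1-c1ccc(Cl)cc1` — 80%

In an in vitro functional assay on HEK285-7 cells for antagonist activity at prostaglandin D2 receptor 2 (Homo sapiens), read by BRET and beta-arrestin recruitment (on this read-out lower numbers stand for smaller maximal responses and higher numbers for larger maximal responses), compound 2 gives 80%. Compound 3 gives 80%, the same number at the digits shown, so the two stand together as the highest of the three values, with no change between them beyond the usual scatter. The furthest from compound 2 is compound 1, which gives 50%, a lower number and clearly beyond the scatter; compound 1 also differs from compound 2 in several places at once, so nothing can be read from it about any single change.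

Compound 4 `O=C(O)Cc1sc(C(c2ccc(F)cc2)c2ccc(F)cc2)nc1-c1ccnc(Cl)c1` has not yet been measured in this assay. It differs from compound 2 in one place: chloro in place of fluoro on an aromatic carbon. Among the measured compounds shown here, no pair of measured compounds shows this change on its own, so there is no measured step to lean on. For the measured compounds named here, an exchange of one halogen for another of the same kind of position is expected to move the maximal response little, if at all, with no step expected beyond the scatter in either direction. On this basis compound 4 is estimated to give 78% in this assay, within a range from 60% to 95%. That estimate means a step of a number 2 percentage points lower from compound 2 to compound 4 (within the scatter), expected to lie within the scatter.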

Compound 4, largest response reached (reported as efficacy), in percent of the reference or control that the assay uses: 80%
For compound 4 the middle estimate is 2 percentage points below the measured one, and the stated range covers the measured number.
By their numbers in this assay, from the lowest: compound 1; then compounds 2, 3 and 4 (each within the scatter of the next).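

In this assay, chloro in place of fluoro on the aromatic carbon next to the ring nitrogen gives no change at the digits printed from compound 2 to compound 4 (within the scatter) as its reading. Among the compounds shown here, this is the first comparison here in which only one place differs, so it isolates a single change that the earlier compounds, which differ in several places at once, could not separate: with the rest of compound 2 kept, either of these two halogens at this position gives the same reading within the scatter. No measurement at hand bears on why the two halogens read alike.

From the compounds shown here alone, whether this position would give a similar reading with an amine, a methoxy group or a nitrile in place of the halogen remains open. The compounds shown also leave open whether chloro in place of fluoro would read the same with the other groups of compound 1 or compound 3 around it.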